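A few compounds are considered here, and "the series" means these few. Any claim that something is new, unique, unknown or untested is made for them only; others in the source may bear on it.

Measured compounds in a functional assay on PC-3 cells (Homo sapiens) for cytotoxicity, read by sulforhodamine B assay, with a stated time of 48 h; a higher number here means a weaker inhibitor, a lower number a stronger inhibitor:
compound 1 `CC1=C(/C=C/C(=O)/C=C/c2ccc(C)cc2)C(C)(C)CCC1` — 21500 nM
compound 2 `COc1cc(/C=C/C(=O)/C=C/C2=C(C)CCCC2(C)C)cc(OC)c1OC` — 32600 nM
compound 3 `CC1=C(/C=C/C(=O)/C=C/C=C/c2ccccc2)C(C)(C)CCC1` — 35400 nM

Compound 3 gives the largest of the three numbers, yet its gaps to compound 2 and to compound 1 both fall inside the usual scatter, so the three compounds are not separated by this assay. Compound 4 `COc1ccccc1/C=C/C=C/C(=O)/C=C/C1=C(C)CCCC1(C)C` differs from compound 3 by methoxy in place of hydrogen on an aromatic carbon. Among the measured compounds shown here, no measured pair shows this particular change, and compound 1 against compound 2 suggests that substitution on that aromatic ring leaves the number roughly where it was. The expected step from compound 3 to compound 4, a 1.2-fold lower number from compound 3 to compound 4 (0.07 log units; within the scatter), is therefore small and not beyond the scatter. Compound 4 is estimated at 30000 nM, between 12000 nM and 75000 nM.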

Compound 4, half-maximal inhibitory concentration: 25300 nM
Compound 4: middle estimate off by 1.2-fold (0.07 log units), on the high side, within the range that was stated.
By their numbers in this assay, from the lowest: compounds 1, 4, 2 and 3 (each within the scatter of the next).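

In this assay methoxy in place of hydrogen on an aromatic carbon, ortho to a large group, gives a 1.4-fold lower number from compound 3 to compound 4 (0.15 log units; within the scatter) and this is the only direct reading of that change among the compounds shown. Phenyl to 2-methoxyphenyl therefore leaves compound 3 and compound 4 unseparated at this position. Nothing at hand accounts for the result.

The compounds shown leave open whether an amine or a carboxylic acid on this aromatic carbon would give a step beyond the scatter. They also leave open whether methoxy elsewhere on this ring would read the same.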